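The source may hold more compounds than are shown below. What is called first, only, known or untested is meant among the compounds shown, and "the series" means these compounds.

Of the compounds shown here, three have so far been tested in a functional assay on SF-295 cells (Homo sapiens) for cytotoxicity, read by sulforhodamine B assay, with a stated time of 48 h; on this read-out lower numbers stand for stronger inhibition of growth and higher numbers for weaker inhibition of growth. Compound 1 `ClCc1ccccc1Cn1cnc2c(Cl)nc(Cl)nc21` gives 1900 nM. Compound 2 `ClCc1ccccc1Cn1cnc2c(Cl)ncnc21` gives 10500 nM. Compound 3 `ClCc1cccc(Cn2cnc3ncnc(Cl)c32)c1` gives 6300 nM; the values of compound 3 and compound 2 lie within the usual scatter of each other. Compound 1 and compound 2 differ in one place, (chloro in place of hydrogen on an aromatic carbon), and this change brought a 5.5-fold lower number from compound 2 to compound 1 (0.74 log units; beyond the scatter).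

Compound 4 `ClCc1cccc(Cn2cnc3nc(Cl)nc(Cl)c32)c1` has not yet been measured in this assay. It differs from compound 3 by the same change, (chloro in place of hydrogen on an aromatic carbon). The difference between the core of compound 3 and the core of compound 2 is not broken down here. Because the earlier change produced a 5.5-fold lower number from compound 2 to compound 1 (0.74 log units; beyond the scatter), a step of similar size is expected, a 5.3-fold lower number from compound 3 to compound 4 (0.72 log units; beyond the scatter). Compound 4 is therefore estimated at 1200 nM, expected to fall between 500 nM and 3000 nM.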

Compound 4, concentration for 50% growth inhibition: 1860 nM
Compound 4: the middle estimate sits 1.6-fold (0.19 log units) below what was measured, within the range that was stated.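

Putting a chloro group on the aromatic carbon between two ring nitrogen atoms gave a 3.4-fold lower number from compound 3 to compound 4 (0.53 log units; beyond the scatter) in this assay. Going by these compounds alone, the change therefore lowered the number on both cores, by steps that cannot be told apart: the same change on two cores in this assay, a 5.5-fold lower number (0.74 log units; beyond the scatter) from compound 2 to compound 1 and a 3.4-fold lower number (0.53 log units; beyond the scatter) from compound 3 to compound 4, 1.6-fold (0.21 log units) apart, within the scatter of two such steps This rests on only two pairs of compounds, so it does not show why the chloro group has this effect or that it would carry over to a third core.

At this ring carbon, the compounds shown hold only hydrogen or chloro. Going by these compounds, whether an amine, a methoxy group or a fluoro group there would lower the number in the same way remains open.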